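The source may report more compounds than this note shows. Statements on the series, on what has been measured and on what is new or still open speak of the compounds shown alone.

Measured in a functional assay on CHO-K1 cells with Glucose-dependent insulinotropic receptor (Homo sapiens) as the target, read by a luciferase reporter, with a stated time of 5 h; on this read-out lower numbers stand for smaller maximal responses and higher numbers for larger maximal responses:
compound 1 `COC(=O)N1CCC(Oc2ncnc3c2CCN3c2ccc(S(C)(=O)=O)cc2F)CC1`: 119%
compound 2 `CCCCOC(=O)N1CCC(Oc2ncnc3c2CCN3c2ccc(S(C)(=O)=O)cc2F)CC1`: 131%
compound 3 `CC(C)COC(=O)N1CCC(Oc2ncnc3c2CCN3c2ccc(S(C)(=O)=O)cc2F)CC1`: 94%

Compound 3 stands lowest of the three numbers, beyond the scatter against both others. The two steps that end on it read a number 25 percentage points lower from compound 1 to compound 3 (beyond the scatter) and a number 37 percentage points lower from compound 2 to compound 3 (beyond the scatter); between the other two, a number 12 percentage points higher from compound 1 to compound 2 (beyond the scatter).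

Compound 4 `CS(=O)(=O)c1ccc(N2CCc3c(OC4CCN(C(=O)OCCF)CC4)ncnc32)c(F)c1` differs from compound 3 in one place: fluoromethyl in place of isopropyl on a saturated chain carbon bound to an oxygen next to a carbonyl group. For the measured compounds named here, no measured step places fluoromethyl on this carbon, so the bearing is indirect. Both steps onto compound 3 carry isopropyl in with a lower number, of modest and large size. Taking isopropyl out again is therefore expected to move the number back up, toward the hydrogen and propyl level, as a number 21 percentage points higher from compound 3 to compound 4 (beyond the scatter). Compound 4 is estimated at 115%, within 92% to 138%.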

Compound 4, largest response reached (reported as percent of maximum), in percent of the reference or control that the assay uses: 86%
Estimate against measurement, compound 4: 29 percentage points above; the whole stated range lies above it.
By their numbers in this assay, from the lowest: compounds 4 and 3 (each within the scatter of the next); then compound 1; then compound 2.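

In this assay the lower level at this carbon is not tied to isopropyl alone: a number 8 percentage points lower from compound 3 to compound 4 (within the scatter), so fluoromethyl and isopropyl sit together there. The same low level holds against both straight-chain esters, with a number 33 percentage points lower from compound 1 to compound 4 (beyond the scatter) and a number 45 percentage points lower from compound 2 to compound 4 (beyond the scatter). No supporting data bear on why these groups give this response. Still open, going by these compounds, is whether a pentyl chain would extend the response seen with the propyl group of compound 2, and how an amine or a carboxylic acid on this carbon would read.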